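Amide aryl variation on the shared core

A few compounds are considered here, and "the series" means these few. Any claim that something is new, unique, unknown or untested is made for them only; others in the source may bear on it.

Three amides of the shared core have been measured in a functional assay on GTL 16 cells for antiproliferative activity against GTL 16 cell line (Homo sapiens), read by CCK-8 assay, with a stated time of 72 h; a lower number here means a stronger inhibitor, a higher number a weaker inhibitor. Compound 1 `O=C(Nc1cccc(-c2oc3cc(-c4ccc(F)cc4)ccc3c(=O)c2O)c1)c1ccccc1F` gives 17400 nM. Compound 2 `Cc1cc(C)cc(C(=O)Nc2cccc(-c3oc4cc(-c5ccc(F)cc5)ccc4c(=O)c3O)c2)c1`, which carries 3,5-dimethylphenyl on the carbonyl carbon, gives 13500 nM. Compound 3 `O=C(Nc1cccc(-c2oc3cc(-c4ccc(F)cc4)ccc3c(=O)c2O)c1)c1cc(F)cc(F)c1`, which carries 3,5-difluorophenyl on the carbonyl carbon, gives 7410 nM, the lowest of the three numbers. Of the three steps on this aryl, a 1.3-fold lower number from compound 1 to compound 2 (0.11 log units; within the scatter) and a 1.8-fold lower number from compound 2 to compound 3 (0.26 log units; within the scatter) stay within the scatter, and only a 2.3-fold lower number from compound 1 to compound 3 (0.37 log units; beyond the scatter) goes beyond it, modestly.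

Compound 4 `N#Cc1ccc(C(=O)Nc2cccc(-c3oc4cc(-c5ccc(F)cc5)ccc4c(=O)c3O)c2)cc1` differs from compound 3 by 4-cyanophenyl in place of 3,5-difluorophenyl on a carbonyl carbon. Within the data shown here, no measured step exchanges the aryl on the carbonyl carbon for a ring bearing a nitrile, so nothing here bears directly on this change. The two steps that do touch this aryl from the same starting point, a 1.3-fold lower number from compound 1 to compound 2 (0.11 log units; within the scatter) and a 2.3-fold lower number from compound 1 to compound 3 (0.37 log units; beyond the scatter), are both small, and the whole spread across the three compounds is narrow. The step of a 1.1-fold higher number from compound 3 to compound 4 (0.06 log units; within the scatter) is therefore expected to stay within the scatter, with no direction claimed. Compound 4 is estimated to give 8500 nM in this assay, with a range of 3500 nM to 20000 nM.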

Compound 4, half-maximal inhibitory concentration: 31800 nM
Compound 4: the middle estimate sits 3.7-fold (0.57 log units) below what was measured; the whole stated range lies below it.
By their numbers in this assay, from the lowest: compounds 3, 2, 1 and 4 (each within the scatter of the next, the first and the last beyond it).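

In this assay the aryl on the carbonyl carbon turns out to be less tolerant than the first three amides suggested: 4-cyanophenyl in place of 3,5-difluorophenyl gives a 4.3-fold higher number from compound 3 to compound 4 (0.63 log units; beyond the scatter), the largest step yet seen at this position. The change from 3,5-dimethylphenyl also registers, with a 2.4-fold higher number from compound 2 to compound 4 (0.37 log units; beyond the scatter), whereas the change from 2-fluorophenyl gives a 1.8-fold higher number from compound 1 to compound 4 (0.26 log units; within the scatter), so compound 4 cannot be separated from compound 1 and the 4-cyanophenyl amide reads alongside the 2-fluorophenyl amide. Nothing available accounts for this step.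

The compounds shown leave open whether the step belongs to the nitrile itself or to the loss of the 3,5-difluorophenyl ring, since no other aryl on the carbonyl carbon separates the two. Also open, from the compounds shown here alone, is how an aryl bearing an amine or a carboxylic acid, or a saturated alkyl chain in place of the aryl, would read in this assay.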